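The compounds below may be only part of what the source reports. "The series", "measured", "known", "first", "only" and "open" are said of these compounds alone.

Two compounds share one core, a bicyclic ring system bearing an isopropyl group and a phenyl ring. Compound 1 `CC(C)n1nc2c(c1-c1ccccc1)CCNCC2` carries an unsubstituted phenyl ring, and in an assay on HEK293 cells for displacement of a labelled ligand from 5-hydroxytryptamine receptor 7 (Rattus norvegicus), read by radioligand binding (on this read-out higher numbers stand for weaker inhibition and lower numbers for stronger inhibition), compound 1 gives 28 nM. Within the data shown here, compound 2 `CC(C)n1nc2c(c1-c1ccc(C#N)cc1)CCNCC2` carries a cyano group on that ring, and in this assay compound 2 gives 90 nM, the higher of the two numbers measured so far; the step of a 3.2-fold higher number from compound 1 to compound 2 (0.51 log units; beyond the scatter) shows what adding a cyano group did here. Compound 3 `CC(C)n1nc2c(c1-c1ccc(C(F)(F)F)cc1)CCNCC2` is not yet measured and differs from compound 2 by trifluoromethyl in place of cyano on an aromatic carbon. Among the measured compounds shown here, no measured step swaps one substituent for another at this position, so the only guide is that a group at this place, in compound 2, gave a modestly higher number than none. A step of no more than the scatter in this assay is expected, a 1.3-fold lower number from compound 2 to compound 3 (0.11 log units; within the scatter), so compound 3 is estimated at 70 nM, within 25 nM to 200 nM.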

Compound 3, inhibition constant: 15 nM
Compound 3: the middle estimate sits 4.7-fold (0.67 log units) above what was measured, and the stated range ends above it.
By their numbers in this assay, from the lowest: compounds 3 and 1 (each within the scatter of the next); then compound 2.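

This position does not treat every group alike: in this assay, trifluoromethyl in place of cyano gives a 6.0-fold lower number from compound 2 to compound 3 (0.78 log units; beyond the scatter) and so shows that the identity of the group counts, not merely the presence of one. Trifluoromethyl in place of hydrogen gives a 1.9-fold lower number from compound 1 to compound 3 (0.27 log units; within the scatter) and so, unlike cyano, leaves the number unchanged as far as the scatter allows anyone to tell. No measurement at hand bears on why the two groups differ in this way.

The compounds shown cover only hydrogen, cyano and trifluoromethyl at this place, so how an amine, a carboxylic acid or a longer chain would fare stays open. They also leave open whether trifluoromethyl on another carbon of the same ring would give a similar number.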